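The compounds below may be only part of what the source reports. "The series", "measured", "known", "first", "only" and "open" are said of these compounds alone.

Of the compounds shown here, three built on a shared core have been measured in a physicochemical assay for lipophilicity, at pH 7.4; on this read-out lower numbers stand for lower lipophilicity and higher numbers for higher lipophilicity. Compound 1 `Cc1cc(C(=O)O)nn1Cc1cc(Br)ccc1OCc1ccccc1` gives 1.2 in this assay. Compound 2 `Cc1cc(C(=O)O)nn1C(C)c1cc(Cl)ccc1OCc1ccccc1` gives 1 in this assay. Compound 3 `Cc1cc(C(=O)Nc2cccc(F)c2)nn1Cc1cc(Cl)ccc1OCc1ccccc1` gives 2.8 in this assay, the highest of the three numbers; its gap to compound 1 and its gap to compound 2 both lie beyond the usual scatter of repeated measurements. Among the compounds with values here, no two of these measured compounds differ in only a single place, so no step between them can be read off directly.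

Compound 4 `Cc1cc(C(=O)NCc2ccccn2)nn1Cc1cc(Cl)ccc1OCc1ccccc1` has not yet been measured. It differs from compound 3 in one place: (pyridin-2-yl)methyl in place of 3-fluorophenyl on an amide-type nitrogen. The group that leaves carries no hydrogen-bond acceptor, while the group that enters carries one. Within the data shown here, no measured pair shows what this kind of swap does in this assay, so the expectation rests on the structural change alone. A downward step of about a number 1.00 log units lower from compound 3 to compound 4 (beyond the scatter) in this assay is expected, a step beyond the scatter. Compound 4 is therefore estimated at 1.8 in this assay, within a range from 1.2 to 2.4.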

Compound 4, distribution coefficient: > 3.7
Compound 4: no number, only a limit; the forecaster's own chance of this, stated with the estimate: 2%; middle value at least 1.90 log units away from the limit.
By their numbers in this assay, from the lowest: compounds 2 and 1 (each within the scatter of the next); then compound 3. At a limit, above all of these: compound 4.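

In this assay, within the data shown here, putting (pyridin-2-yl)methyl in place of 3-fluorophenyl on an amide-type nitrogen gives a number at least 0.90 log units higher from compound 3 to compound 4 (beyond the scatter), the first step that can be read between two compounds differing in one place. This shows that the group on this nitrogen can move the read-out by more than the scatter, and that in this one pair the number goes up even though the entering group carries one hydrogen-bond acceptor and the leaving group carries none. The reading for compound 4 is a limit of the assay and not a number, so the step has a lower bound but no known size: the limit of > 3.7 in this assay, at which 1 of the 4 values shown sits.

This single swap changes the ring, removes the fluorine and alters the link to the amide-type nitrogen all at once, and the compounds shown do not tell which of these changes carries the step, or how large it really is. From the compounds shown here alone, a benzyl group on the same nitrogen, with a carbon-only ring and the same kind of link as (pyridin-2-yl)methyl, would help separate these changes, but its effect in this assay remains open here.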